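The source may hold more compounds than are shown below. What is called first, only, known or untested is meant among the compounds shown, and "the series" means these compounds.

Working notes. Compound 1 `CCC1C(=O)N(C)c2cnc(Nc3ccc(S(=O)(=O)NC)cc3)nc2N1c1ccn(C)n1` gives the lowest of the two numbers measured in an assay for inhibition of serine/threonine-protein kinase PLK2 (Homo sapiens), read by FRET and Z'-LYTE, with a stated time of 1 h (on this read-out higher numbers stand for weaker inhibition and lower numbers for stronger inhibition), at 71.6 nM. Compound 2 `CC[C@@H]1C(=O)N(C)c2cnc(-n3ccc4cc(F)ccc43)nc2N1C1CCCC1` gives 969 nM in this assay, a higher number beyond the scatter; the two structures differ in several places at once, so this pair shows only its two values. Compound 3 `CCC1C(=O)N(C)c2cnc(Nc3ccc(S(=O)(=O)NCCCO)cc3)nc2N1c1ccn(C)n1` is not yet measured; it differs from compound 1 by 2-hydroxyethyl in place of hydrogen on a saturated chain carbon bound to a sulfonamide nitrogen. Among the measured compounds shown here, no step of this kind has been measured, so the expectation for a 1.1-fold higher number from compound 1 to compound 3 (0.05 log units; within the scatter) is no change beyond the scatter in either direction. Compound 3 is accordingly estimated at 80 nM, within a range from 30 nM to 250 nM.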

Compound 3, half-maximal inhibitory concentration: 192 nM
For compound 3 the middle estimate is 2.4-fold (0.38 log units) below the measured one; the range from low to high includes it.
By their numbers in this assay, from the lowest: compound 1; then compound 3; then compound 2.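

Among the compounds shown here, on the sulfonamide nitrogen, methyl to 3-hydroxypropyl is the first single-place change, and in this assay it gives a 2.7-fold higher number from compound 1 to compound 3 (0.43 log units; beyond the scatter), a modest loss that leaves inhibition measurable in the same range as compound 1. This position therefore accepts the larger hydroxylated chain, but at some cost. Nothing available explains the size of this step.

Whether the chain or its hydroxyl accounts for the step stays open. Propyl or 3-aminopropyl on the same nitrogen would separate the two.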